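A few compounds are considered here, and "the series" means these few. Any claim that something is new, unique, unknown or untested is made for them only; others in the source may bear on it.

Of the compounds shown here, two have so far been measured in a functional assay on HeLa cells (Homo sapiens) for cytotoxicity, read by MTT assay, with a stated time of 2 days, tested at 0.1 uM; a higher number here means a weaker effect of the compound at the concentration tested, a lower number a stronger effect. Compound 1 `COc1ccc(-c2cc3cc(-c4ccc(F)cc4)cc(C(C)=O)c3[nH]2)cc1` gives 81% in this assay, and compound 2 `CC(=O)c1cc(/C=C/c2ccc(F)cc2)cc2cc(-c3ccc(F)cc3)[nH]c12` gives 72.6% in this assay; the two numbers lie within the scatter of each other, so on the numbers shown compound 2 cannot be told apart from compound 1. Compound 3 `COc1ccc(-c2cc3cc(/C=C/c4ccc(F)cc4)cc(C(C)=O)c3[nH]2)cc1` is not yet measured in this assay. It differs from compound 2 in one place, (methoxy in place of fluoro on an aromatic carbon), the change sitting para to a large group. Among the measured compounds shown here, no step between measured compounds is known for this change. The step expected in this assay is none beyond the scatter, a number 4.4 percentage points higher from compound 2 to compound 3 (within the scatter), because compound 1 carries the same 4-methoxyphenyl and gives 81%. Compound 3 is therefore estimated to give about 77% in this assay, with a range from 62% to 90%.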

Compound 3, a percentage reported as activity, at one concentration (the size of the read-out at that concentration, not a potency): 90.5%
Compound 3: middle estimate off by 13.5 percentage points, on the low side; the measured number lies above the stated range.
By their numbers in this assay, from the lowest: compounds 2, 1 and 3 (each within the scatter of the next, the first and the last beyond it).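

In this assay the change from 4-fluorophenyl to 4-methoxyphenyl now has a first step, a number 17.9 percentage points higher from compound 2 to compound 3 (beyond the scatter), beyond the scatter, so with the 2-(4-fluorophenyl)ethenyl group held constant, the methoxy compound shows the weaker effect at the concentration tested. The exchange of 4-fluorophenyl for 2-(4-fluorophenyl)ethenyl, with the 4-methoxyphenyl held constant, gives a number 9.5 percentage points higher from compound 1 to compound 3 (within the scatter), within the scatter, so these numbers do not separate the two groups at that place. Nothing at hand gives a reason for the methoxy step.

As far as these compounds go, this methoxy step rests on a single pair, and whether it carries over to other substituents at the second place remains open. Also open, from the compounds shown here alone, is how a hydroxyl, an amine or a carboxylic acid on this aromatic carbon would read against fluoro and methoxy.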